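Changing one ring group on compound 1

A few compounds are considered here, and "the series" means these few. Any claim that something is new, unique, unknown or untested is made for them only; others in the source may bear on it.

- compound 1 `COc1cc([C@](O)(CCN(C)C)[C@@H](c2cc3cc(Br)ccc3nc2OC)c2cccc(OC)c2F)cc(OC(C)C)n1` gives 9000 ng.h/mL
- compound 2 `COc1cc([C@](O)(CCN(C)C)[C@@H](c2cc3cc(Br)ccc3nc2OC)c2ccnc(OC)c2OC)cc(OC(C)C)n1` gives 5600 ng.h/mL
- compound 3 `COc1cc([C@](O)(CCN(C)C)[C@@H](c2cc3cc(C#N)ccc3nc2OC)c2ccnc(OC)c2OC)cc(N(C)C)n1` gives 3300 ng.h/mL

Compound 1 sits at the upper end of these three numbers in an ADME assay on the whole organism (Mus musculus, strain CD-1) for pharmacokinetics, at a dose of 10 mg/kg by the oral route (a lower number here means less compound in the circulation, a higher number more compound in the circulation at the dose given), and its number is clearly apart only from that of compound 3. Compound 4 `COc1cccc([C@H](c2cc3cc(Br)ccc3nc2OC)[C@@](O)(CCN(C)C)c2cc(SC)nc(SC)c2)c1F` has not yet been measured. Compared with compound 1 it carries a group of 10 heavy atoms (7 carbon, 1 nitrogen, 2 sulfur; one six-membered aromatic ring with 1 hetero atom) in place of a group of 12 heavy atoms (9 carbon, 1 nitrogen, 2 oxygen; one six-membered aromatic ring with 1 hetero atom), on a saturated chain carbon bound to an oxygen on a saturated carbon and two saturated chain carbons and differs nowhere else. Among the compounds with values here, no measured compound contains sulfur, and no measured step touches this place. The nearest guide is a 1.6-fold lower number from compound 1 to compound 2 (0.21 log units; within the scatter), which swaps a different aromatic group. Compound 3 at 3300 ng.h/mL differs from the others in more than one place, so its number cannot be pinned on a single change. With so little to go on, no step beyond the scatter is expected in this assay, in either direction, though the uncertainty is wide. The estimated shift is a 1.5-fold lower number from compound 1 to compound 4 (0.18 log units; within the scatter) and counts as small. For compound 4 the expected value is 6000 ng.h/mL, with an estimated range from 2000 ng.h/mL to 16000 ng.h/mL for this new group.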

Compound 4, area under the concentration-time curve: 8400 ng.h/mL
Beside the measured number, compound 4's estimate is 1.4-fold (0.15 log units) below it; the measured number falls inside the stated range.
By their numbers in this assay, from the lowest: compounds 3, 2, 4 and 1 (each within the scatter of the next, the first and the last beyond it).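

This place, the saturated chain carbon bound to an oxygen on a saturated carbon and two saturated chain carbons, now has a measured step of its own in this assay: the sulfur-bearing group replaces the group with two oxygens, giving a 1.1-fold lower number from compound 1 to compound 4 (0.03 log units; within the scatter), so the two compounds cannot be told apart. The swap therefore shows that, in this assay, the place tolerates one ring group with two sulfur atoms in exchange for one with two oxygen atoms and a larger heavy-atom count, with no step beyond the scatter. Nothing available accounts for this result.

From the compounds shown here alone, it remains open whether a ring at this place carrying a carboxylic acid or a morpholine would leave the number just as unmoved. Also open, going by these compounds, is whether the same swap would hold with 2,3-dimethoxypyridin-4-yl in place of 2-fluoro-3-methoxyphenyl.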